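This account rests on a few compounds, and the source may have more. Where it says the series, first, only, none or still open, it means among the compounds named here.

Three compounds of a shared core, each a urea joined to a piperidine that carries an acyl group, have been measured in a physicochemical assay for lipophilicity, read by HPLC, with a stated time of 90 min, tested at 100 uM; a higher number here means a more lipophilic compound, a lower number a more polar compound. Compound 1 `O=C(Nc1ccc(OC(F)(F)F)cc1)NC1CCN(C(=O)c2ccoc2)CC1` gives 3.63 in this assay. Compound 2 `CC(C)C(=O)N1CCC(NC(=O)Nc2ccc(C(F)(F)F)c(F)c2)CC1` gives 4.4, and compound 3 `CC[C@H](C)C(=O)N1CCC(NC(=O)Nc2ccc(C(F)(F)F)cn2)CC1` gives 3.22. Among these three numbers compound 1 stands second highest: compound 3 lies below it by a gap beyond the scatter, and compound 2 lies above it by a larger gap, also beyond the scatter. Each pair differs in more than one place, so no single change can be read out of these steps.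

Compound 4 `O=C(Nc1ccc(OC(F)(F)F)cc1)NC1CCN(C(=O)[C@@H]2CCOC2)CC1` differs from compound 1 in one place only: oxolan-3-yl in place of furan-3-yl on a carbonyl carbon. This trades an aromatic five-membered ring for a saturated one of the same size and the same count of hetero atoms, on the acyl group of the piperidine.

Within the data shown here, no measured pair shows this change, so the expectation rests on the structures alone. The step from compound 1 to compound 4 in this assay is expected to be a modest decrease, a number 0.53 log units lower from compound 1 to compound 4 (beyond the scatter), clearly beyond the scatter. Compound 4 is therefore estimated at 3.1, with a likely range from 2.7 to 3.5.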

Compound 4, partition coefficient: 3.38
Compound 4: middle estimate off by 0.28 log units, on the low side, and the stated range covers the measured number.
By their numbers in this assay, from the lowest: compounds 3, 4 and 1 (each within the scatter of the next, the first and the last beyond it); then compound 2.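

Among these compounds, this is the first pair here that differs in one place only, so a single change can now be read: on a carbonyl carbon whose other neighbours are an amide-type nitrogen in a ring, oxolan-3-yl in place of furan-3-yl gives, in this assay, a number 0.25 log units lower from compound 1 to compound 4 (within the scatter). Losing the aromatic character of this five-membered ring, while keeping its heavy atoms, its oxygen and its single hydrogen-bond acceptor, therefore leaves two compounds that this measurement cannot tell apart. No measured information is available to explain why the step is this small.

This single pair cannot show whether the same exchange would give a similar step with a different group at the other end of the urea, or whether the opposite configuration at the defined stereocentre of the oxolan-3-yl group would read the same. It also leaves open how the number would respond if a group of a different kind stood on the same carbonyl carbon, such as a ring carrying a basic amine or a carboxylic acid, or a longer open alkyl chain.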